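Trifluoromethyl in Place of Cyano on Two Cores

The source may report more compounds than this note shows. Statements on the series, on what has been measured and on what is new or still open speak of the compounds shown alone.

compound 1, `CC1(C)Oc2ccc(C#N)cc2[C@@H](N2CCCCC2=O)[C@@H]1O`: 270 nM
compound 2, `CC1(C)Oc2ccc(C(F)(F)F)cc2[C@@H](N2CCCCC2=O)[C@@H]1O`: 58 nM
compound 3, `CC1(C)C=C(n2ccccc2=O)c2cc(C#N)ccc2O1`: 89 nM

All three compounds were tested in a functional assay (trachea) for inhibition, with Cavia porcellus as the target; a lower number here means a stronger inhibitor, a higher number a weaker inhibitor. Compound 1 and compound 2 share one core and differ in a single place: trifluoromethyl in place of cyano on an aromatic carbon. That one change gave a 4.7-fold lower number from compound 1 to compound 2 (0.67 log units; beyond the scatter).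

Compound 3 rests on a different core; how the core of compound 3 differs from the core of compound 1 is not broken down here. In this assay the number for compound 3 lies close to that of compound 2, within the usual scatter, and below that of compound 1.

Compound 4, `CC1(C)C=C(n2ccccc2=O)c2cc(C(F)(F)F)ccc2O1`, has not yet been measured in this assay. It differs from compound 3 in exactly the way compound 2 differs from compound 1: trifluoromethyl in place of cyano on an aromatic carbon. The group sits on the same kind of ring at the same kind of position in both pairs, so this is the same change, now made on the second core. If it shifts the number on the core of compound 3 as it did on the core of compound 1, compound 4 is expected to show a step of about a 3.6-fold lower number from compound 3 to compound 4 (0.55 log units; beyond the scatter). Whether a shift seen once on one core carries over to another cannot be known from a single pair, so the range is kept wide. Compound 4 is therefore estimated at 25 nM, between 9 nM and 70 nM.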

Compound 4, half-maximal inhibitory concentration: 56 nM
Estimate against measurement, compound 4: 2.2-fold (0.35 log units) below; the measured number falls inside the stated range.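

On the core of compound 3, the change from cyano to trifluoromethyl gives a 1.6-fold lower number from compound 3 to compound 4 (0.20 log units; within the scatter) in this assay, so this pair cannot be told apart in this test, even though the same swap clearly moved the number on the first core. The size of the shift therefore did not carry over from one core to the other, and the gap between the two steps is larger than repeated measurements would explain: the same change on two cores in this assay, a 4.7-fold lower number (0.67 log units; beyond the scatter) from compound 1 to compound 2 and a 1.6-fold lower number (0.20 log units; within the scatter) from compound 3 to compound 4, 2.9-fold (0.47 log units) apart, beyond the scatter of two such steps. For the compounds shown here, this shows that, in this series, a step seen on one core is not a safe guide to the step on another, but with only two pairs it does not show why the cores differ, nor how any other change would carry over.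

On these data alone, whether a chlorine atom, a nitro group or a simple methyl group on the same aromatic carbon would also give different steps on the two cores remains open. As far as these compounds go, it is equally open whether the difference between the cores belongs to trifluoromethyl alone or would appear with other replacements for cyano.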